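Compound 4 measured against a limit shared by three

The source may report more compounds than this note shows. Statements on the series, on what has been measured and on what is new or still open speak of the compounds shown alone.

Of the compounds shown here, three of one shared core have been measured in an assay on CHO cells for displacement of a labelled ligand from adenosine receptor A3 (Homo sapiens), read by scintillation counting, with a stated time of 45 min, in the presence of a further agent that is not named here; a higher number here means a weaker inhibitor, a lower number a stronger inhibitor. Compound 1 `CCCn1c(=O)c2[nH]c(-c3ccc(S(=O)(=O)N4CCN(c5ccc(Cl)cc5)CC4)cc3)nc2n(CC)c1=O` gives only a limit, > 1000 nM, in this assay. Compound 2 `CCCn1c(=O)[nH]c2nc(-c3ccc(S(=O)(=O)N4CCN(c5cccc(Br)c5)CC4)cc3)[nH]c2c1=O` likewise returns a limit, > 1000 nM. Compound 3 `CCCn1c(=O)[nH]c2nc(-c3ccc(S(=O)(=O)N4CCN(C)CC4)cc3)[nH]c2c1=O` also returns a limit, > 1000 nM, so it stands at the same edge of the assay as the other two and not at a number. Among the measured compounds shown here, the one step between measured compounds, a step that the two limits leave unreadable from compound 2 to compound 3, cannot be read because the limit of > 1000 nM in this assay, at which 3 of the 3 values shown sit, hides both of its ends.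

Compound 4 `CCCn1c(=O)[nH]c2nc(-c3ccc(S(=O)(=O)N4CCN(Cc5ccc(Br)cc5)CC4)cc3)[nH]c2c1=O` differs from compound 3 in that (4-bromophenyl in place of hydrogen on a saturated chain carbon bound to an amine nitrogen in a ring). For the measured compounds named here, no measured step gives a readable size for such a change: the only comparison available, a step that the two limits leave unreadable from compound 2 to compound 3, is swallowed by the limit, and the whole set shows nothing beyond (the limit of > 1000 nM in this assay, at which 3 of the 3 values shown sit). There is therefore no footing for expecting a shift beyond the scatter in either direction, and the most that can be said is that compound 3 and its relatives all sit past the reach of the assay.

On that basis compound 4 is expected to give about 3000 nM in this assay, within 500 nM to 30000 nM, and most probably once more only a limit. The implied step that the limit leaves unreadable from compound 3 to compound 4 is an estimate rather than a reading.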

Compound 4, inhibition constant: > 1000 nM
Compound 4: a limit, no number; the forecaster's own chance of this, stated with the estimate: 70%; the middle value does not contradict the limit.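

In this assay compound 4 returns > 1000 nM, which is a limit and not a number. Neither the step from compound 3 to compound 4 nor that from compound 2 to compound 4 can be read, because both ends are hidden: the limit of > 1000 nM in this assay, at which 4 of the 4 values shown sit.

The compounds shown leave open what inhibition constant any of them has, and whether methyl, 3-bromophenyl and 4-bromobenzyl on the amine nitrogen in a ring differ at all.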